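The source may report more compounds than this note shows. Statements on the series, on what has been measured and on what is new or still open speak of the compounds shown alone.

Measured compounds:
compound 1, `CCN1CCN(c2c(S(=O)(=O)c3ccccc3)cnc3ccccc23)CC1`, 1.7%
compound 2, `Cc1ccc2ncc(S(=O)(=O)c3ccc(C)c(F)c3)c(N3CCC(C)CC3)c2c1`, 91%
compound 3, `Cc1cc(C)cc(S(=O)(=O)c2cnc3cc(F)ccc3c2N2CCC(C)CC2)c1`, 80%

In an assay on isolated protein for displacement of a labelled ligand from metabotropic glutamate receptor 5 (Homo sapiens), with a stated time of 60 min, tested at 1 uM (a lower number here means less inhibition, a higher number more inhibition at the concentration tested (going by the name of the read-out)), compound 3 gives 80%, which places it second highest among the three numbers. Its closest neighbour is compound 2, whose value lies higher by a margin beyond the usual scatter, and its most distant one is compound 1, whose value lies far lower, also beyond the scatter. Compounds 2 and 3, which both carry a methyl-substituted phenyl on the sulfonyl sulfur, sit well above compound 1.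

Compound 4, `COc1ccc(S(=O)(=O)c2cnc3cc(F)ccc3c2N2CCC(C)CC2)cc1OC`, has not yet been measured in this assay. It differs from compound 3 in one place: 3,4-dimethoxyphenyl in place of 3,5-dimethylphenyl on a sulfonyl sulfur. The 3,4-dimethoxyphenyl brings two hydrogen-bond acceptors where the 3,5-dimethylphenyl had none. Within the data shown here, nothing among the measured compounds shows what a change of this kind does, so only a cautious expectation is possible. A modest step downward, possibly within the scatter, is expected from compound 3 to compound 4, namely a number 15 percentage points lower from compound 3 to compound 4 (beyond the scatter). For compound 4 the estimated value in this assay is 65%, with a range from 30% to 90%.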

Compound 4, a percentage reported as inhibition, at one concentration (the size of the read-out at that concentration, not a potency): 83%
Estimate against measurement, compound 4: 18 percentage points below, within the range that was stated.
By their numbers in this assay, from the lowest: compound 1; then compounds 3, 4 and 2 (each within the scatter of the next, the first and the last beyond it).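

In this assay, replacing 3,5-dimethylphenyl with 3,5-dimethylphenyl's 3,4-dimethoxyphenyl counterpart on a sulfonyl sulfur gives a number 3 percentage points higher from compound 3 to compound 4 (within the scatter), so this pair cannot be told apart in this read-out. For this one pair, then, a group with more heavy atoms and with hydrogen-bond acceptors, which 3,5-dimethylphenyl lacks, leaves the inhibition in this assay level. No independent measurement offers an explanation for this result.

From the compounds shown here alone, the read-out is taken at one concentration and is not a potency, so any difference in potency between compound 3 and compound 4 remains open. Also open, going by these compounds, is what a phenyl bearing an amine or a carboxylic acid would do on the same sulfonyl sulfur, with the rest of the compound unchanged.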